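Chloro for methyl on the fused ring of compound 2

The source may report more compounds than this note shows. Statements on the series, on what has been measured and on what is new or still open speak of the compounds shown alone.

Measured so far in a functional assay on the whole organism for inhibition, with Chenopodium ficifolium as the target, with a stated time of 72 h, tested at 10 mg/L; on this read-out lower numbers stand for less inhibition of growth and higher numbers for more inhibition of growth at the one concentration tested:
compound 1 `Cc1cc(O)nc(NC(=S)NC(=O)c2c(-c3ccc(Cl)cc3Cl)noc2C)n1`: -5.86%
compound 2 `COc1cc(C)nc2n/c(=N/C(=O)c3c(-c4ccc(Cl)cc4Cl)noc3C)sn12`: 45.7%
compound 3 `CSc1cc(C)nc2n/c(=N/C(=O)c3c(-c4ccc(Cl)cc4Cl)noc3C)sn12`: 21.9%

Compound 2 gives the highest number of the three; compound 3 lies beyond the scatter below it, and compound 1, which carries a different core, lies far below both. Going by the values given here, the one single-point step on record, methylsulfanyl for methoxy, gave a number 23.8 percentage points lower from compound 2 to compound 3 (beyond the scatter).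

Compound 4 `COc1cc(Cl)nc2n/c(=N/C(=O)c3c(-c4ccc(Cl)cc4Cl)noc3C)sn12` differs from compound 2 by chloro in place of methyl on an aromatic carbon. Among the compounds with values here, no measured step touches this position, so the methoxy-to-methylsulfanyl step is only a rough guide to how much a small exchange on this ring can move this assay. A modest change in either direction is plausible; none beyond the scatter is the central expectation, with the step estimated as a number 3.7 percentage points lower from compound 2 to compound 4 (within the scatter).

Compound 4 is therefore expected to give 42% in this assay, within a range of 12% to 70%.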

Compound 4, percent growth inhibition at one concentration: 19.3%
Estimate against measurement, compound 4: 22.7 percentage points above; the measured number falls inside the stated range.
By their numbers in this assay, from the lowest: compound 1; then compounds 4 and 3 (each within the scatter of the next); then compound 2.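

In this assay this carbon of the fused ring proves responsive: chloro in place of methyl gives a number 26.4 percentage points lower from compound 2 to compound 4 (beyond the scatter). Until now, the only recorded single-place step was at the methoxy group, so methyl is the first group on this side of the ring shown to matter, and both exchanges from compound 2 lower the number. Nothing measured here accounts for the drop. Open, as far as these compounds go, is whether an ethyl group, an amine or trifluoromethyl at this carbon would hold the number of compound 2. From the compounds shown here alone, whether chloro lowers the number to the same extent alongside methylsulfanyl also stays open.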